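Swapping the Formyl Group on a Cytotoxic Compound

This account rests on a few compounds, and the source may have more. Where it says the series, first, only, none or still open, it means among the compounds named here.

In an ADME assay on HEK293 cells (Homo sapiens) for cytotoxicity, with a stated time of 72 h (a higher number here means that more compound is needed for the effect, a lower number that less compound is needed), compound 1 `C=C[C@@](C)(/C=C/c1ccc(O)cc1)CC/C=C(C)/C=N/N` gives > 36600 nM as a limit of the assay and not a number. Compound 2 `C=C[C@@](C)(/C=C/c1ccc(O)c(CO)c1)CCC=C(C)C` likewise gives > 36600 nM as a limit. Going by the values given here, compound 3 `COc1ccc(/C=C/[C@@](C)(/C=C/c2ccc(O)c(C=O)c2)CCC=C(C)C)cc1` gives 2270 nM and so stands as the only compound here with an actual number.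

Compound 4 `CCOC(=O)/C(C)=C/c1cc(/C=C/[C@](C)(/C=C/c2ccc(OC)cc2)CCC=C(C)C)ccc1O` carries 2-(ethoxycarbonyl)prop-1-en-1-yl in place of the formyl of compound 3 on an aromatic carbon, ortho to a hydroxy group (2-(ethoxycarbonyl)prop-1-en-1-yl in place of formyl on an aromatic carbon). The entering group is the larger, but no measured step between any of these compounds shows what such a change does, so the expectation is loose. It starts from compound 3 at 2270 nM and leans towards more compound being needed.

A modest estimated step of a 2.6-fold higher number from compound 3 to compound 4 (0.42 log units; beyond the scatter) is expected in this assay with a wide margin on either side. Compound 4 is expected at 6000 nM within an estimated range of 1500 nM to 30000 nM in this measurement.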

Compound 4, half-maximal effective concentration: > 36600 nM
Compound 4 was reported as a limit (the forecaster's own chance of this, stated with the estimate: 25%); at least 6.1-fold (0.78 log units) between middle value and limit.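

Going by these compounds alone, on an aromatic carbon, ortho to a hydroxy group, putting 2-(ethoxycarbonyl)prop-1-en-1-yl in place of formyl gives an at least 16-fold higher number from compound 3 to compound 4 (1.20 log units; beyond the scatter) in this assay and provides the first comparison here of compounds differing in one place. Compound 4 gives > 36600 nM as a limit of the assay and not a number. The true size of the step cannot be read, because the result for compound 4 rests on a limit shared with other compounds: the limit of > 36600 nM in this assay, at which 3 of the 4 values shown sit.

Going by these compounds, whether the formyl itself is needed for a measurable number, or whether another small group would serve equally well at this position, remains open. An acetyl, a carboxylic acid or an aminomethyl group in its place would help to separate these possibilities.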